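From two nitrooxy chains to one

The compounds below may be only part of what the source reports. "The series", "measured", "known", "first", "only" and "open" are said of these compounds alone.

compound 1 `O=C(/C=C/c1ccc(OCCCCO[N+](=O)[O-])c(O)c1)OCCCCO[N+](=O)[O-]` gives > 50000 nM (a limit, not a number)
compound 2 `COc1cc(/C=C/C(=O)OCCCO[N+](=O)[O-])ccc1OCCCO[N+](=O)[O-]` gives 1420 nM
compound 3 `COc1cc(/C=C/C(=O)Oc2ccc(OCc3c(-c4ccccc4)no[n+]3[O-])cc2)ccc1O` gives 28800 nM

All three values come from a functional assay on Calu-1 cells (Homo sapiens) for cytotoxicity, read by resazurin assay, with a stated time of 72 h (on this read-out lower numbers stand for stronger inhibition and higher numbers for weaker inhibition), as the common test. Compound 2 at 1420 nM holds the lower of the two true numbers, and compound 3 at 28800 nM lies well beyond the usual scatter from it. Compound 1 reaches only a limit of the assay (> 50000 nM) and it gives no true number.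

Compound 4 `COc1cc(/C=C/C(=O)OCCCO[N+](=O)[O-])ccc1O` has not been measured yet. Its difference from compound 2 is hydrogen in place of 3-(nitrooxy)propyl on an oxygen on an aromatic ring so that 3-(nitrooxy)propoxy becomes hydroxy. Going by the values given here, no measured pair isolates this change, so any forecast is tentative. A rise in the number, beyond the scatter, is expected because compound 3 at 28800 nM also keeps a hydroxy on an aromatic ring, although it differs from compound 2 elsewhere too. The expected size is a 13-fold higher number from compound 2 to compound 4 (1.10 log units; beyond the scatter) as a rough estimate. For compound 4 the estimated value is 18000 nM with an expected range from 5000 nM to 50000 nM in this test.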

Compound 4, half-maximal inhibitory concentration: > 50000 nM
Compound 4: a limit, no number; the forecaster's own chance of this, stated with the estimate: 25%; middle value at least 2.7-fold (0.44 log units) away from the limit.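

Taking the 3-(nitrooxy)propyl off the oxygen on the aromatic ring, so that 3-(nitrooxy)propoxy becomes hydroxy, is the first change here that can be read on its own, and this assay shows an at least 35-fold higher number from compound 2 to compound 4 (1.54 log units; beyond the scatter). The 3-(nitrooxy)propyl that compound 4 still carries therefore does not, alone, give a true number in this test. The step is only a lower bound, because compound 4 stops at a limit rather than a number: the limit of > 50000 nM in this assay, at which 2 of the 4 values shown sit.

The compounds shown leave open whether the nitrooxy group at the end of this chain matters or the chain itself, which a plain propyl on the same oxygen would separate. They also do not tell how a longer chain ending in nitrooxy at this oxygen would read in this assay.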